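Nitro in place of hydrogen on the core of compound 1

The source may hold more compounds than are shown below. What is called first, only, known or untested is meant among the compounds shown, and "the series" means these compounds.

For the measured compounds named here, compound 1 `CCCCCn1c(N)nc2ccccc21` is the only member of the series with a number: in an assay on HEK293 cells for agonist activity at Toll-like receptor 8 (Homo sapiens), read by reporter gene assay (on this read-out higher numbers stand for an effect only at larger amounts of compound and lower numbers for an effect already at smaller amounts), compound 1 gives 3230 nM. Compound 2 `CCCCCn1c(N)nc2cccnc21` carries a nitrogen in the fused ring and in this assay compound 2 gives "not active" (no number reported), with no number reported. Compound 3 `CCCCCn1c(N)nc2c([N+](=O)[O-])cccc21` differs from compound 1 by nitro in place of hydrogen on an aromatic carbon. Going by the values given here, no measured step of this kind exists, so nothing shows how this assay responds to a nitro here. The expectation is a step of a 1.3-fold lower number from compound 1 to compound 3 (0.11 log units; within the scatter) that stays within scatter. Compound 3 is estimated at 2500 nM, with a range from 600 nM to 10000 nM.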

Compound 3, half-maximal effective concentration: "not active" (no number reported)
No number was reported for compound 3; the estimate stays without a comparison.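

For the compounds shown here, compound 3 has no reported number, so no step from compound 1 can be read. The compounds shown leave open whether any substituent on the shared core keeps a measurable number. No evidence bears on this result.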